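The source may report more compounds than this note shows. Statements on the series, on what has been measured and on what is new or still open speak of the compounds shown alone.

The measured compounds:

compound 1, `Fc1cccc(F)c1C#Cc1cncc2ccccc12`, 87.9%
compound 2, `Fc1cccc(F)c1C#Cc1cnc(Cl)c2ccccc12`, 94%
compound 3, `Fc1cccc(F)c1C#Cc1ccc2ncccc2c1`, 80.1%

All three were tested in a functional assay on LS174T cells (Homo sapiens) for inhibition, with a stated time of 4 days, tested at 10 uM; a higher number here means a stronger effect of the compound at the concentration tested, a lower number a weaker effect. Compound 1 and compound 2 differ by one change, (chloro in place of hydrogen on an aromatic carbon), and that change made a step of a number 6.1 percentage points higher from compound 1 to compound 2 (within the scatter). Compound 3 has the same atoms as compound 1 joined differently; the difference between the two cores is not broken down here. Compound 3 gives the lowest number of the three, though its gap to compound 1 lies within the scatter and only its gap to compound 2 lies beyond it.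

Compound 4, `Fc1cccc(F)c1C#Cc1ccc2nc(Cl)ccc2c1`, has not yet been measured. It differs from compound 3 by chloro in place of hydrogen on an aromatic carbon. This is the same kind of change as that from compound 1 to compound 2, but not the same: in compound 2 the chloro sits ortho to a fused ring and para to a large group, whereas in compound 4 it sits para to a fused ring. On the core of compound 3 the same kind of change is expected to make a step of about a number 5.9 percentage points higher from compound 3 to compound 4 (within the scatter), resting on the step of a number 6.1 percentage points higher from compound 1 to compound 2 (within the scatter) seen on the other core. Compound 4 is therefore estimated to give 86% in this assay, most likely between 72% and 96%.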

Compound 4, a percentage reported as inhibition, at one concentration (the size of the read-out at that concentration, not a potency): 63.3%
Beside the measured number, compound 4's estimate is 22.7 percentage points above it; measured number outside the range, below it.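

In this assay, chloro in place of hydrogen on an aromatic carbon, here next to the ring nitrogen, makes a step of a number 16.8 percentage points lower from compound 3 to compound 4 (beyond the scatter). For the compounds shown here, the change therefore does not carry from one core to the other with the same size or direction: the same change on two cores in this assay, a number 6.1 percentage points higher (within the scatter) from compound 1 to compound 2 and a number 16.8 percentage points lower (beyond the scatter) from compound 3 to compound 4, 22.9 percentage points apart, beyond the scatter of two such steps This shows that the result of the change on one core was no safe guide to its result on the other, but with only one pair on each core and the chloro in a different place on each, it does not show whether the core or the place accounts for the gap, nor does it yield any rule for other cores.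

The compounds shown leave open whether a methyl, a methoxy or an amine on that same carbon of the core of compound 3 would follow chloro in compound 4 or go the other way. They also leave open how chloro on the other aromatic carbons of that core would behave, and, since each number comes from one concentration, whether the effect would be stronger or weaker at any other concentration.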